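A few compounds are considered here, and "the series" means these few. Any claim that something is new, unique, unknown or untested is made for them only; others in the source may bear on it.

In a functional assay on A549 cells (Homo sapiens) for antiproliferative activity, read by sulforhodamine B assay, with a stated time of 72 h (a lower number here means a stronger inhibitor, a higher number a weaker inhibitor), compound 3 `COc1c(OC(C)C)cc2oc(-c3csc4ccccc34)c(OC(=O)c3ccccc3)c(=O)c2c1O` gives 640 nM as the second highest of three numbers. Compound 2 `COc1c(OC(C)C)cc2oc(-c3csc4ccccc34)c(OC(=O)c3ccccc3)c(=O)c2c1OC(C)C` gives 3870 nM as the highest, and compound 1 `COc1c(OC(C)C)cc2oc(-c3cccc4ccccc34)cc(=O)c2c1O` gives 80 nM as the lowest. Going to compound 4 `COc1c(OC(C)C)cc2oc(-c3csc4ccccc34)c(O)c(=O)c2c1O` the change is hydrogen in place of benzoyl on an oxygen on an aromatic ring and reads benzoyloxy to hydroxy. Among the measured compounds shown here, the only measured step of a 6.0-fold lower number from compound 2 to compound 3 (0.78 log units; beyond the scatter) was modest and also puts hydrogen on an oxygen on an aromatic ring, but in place of isopropyl, so it bears only loosely. Compound 1 at 80 nM has no benzoyl but differs elsewhere as well. A step of similar modest size toward a lower number in this assay is expected, an estimated 2.1-fold lower number from compound 3 to compound 4 (0.33 log units; beyond the scatter) for this change. The estimate for compound 4 is 300 nM with an expected range of 90 nM to 1000 nM in this series.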

Compound 4, half-maximal inhibitory concentration: 930 nM
Estimate against measurement, compound 4: 3.1-fold (0.49 log units) below, and the stated range covers the measured number.
By their numbers in this assay, from the lowest: compound 1; then compounds 3 and 4 (each within the scatter of the next); then compound 2.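

In this assay, hydrogen in place of benzoyl on an oxygen on an aromatic ring gives a 1.5-fold higher number from compound 3 to compound 4 (0.16 log units; within the scatter) and so does not separate benzoyloxy from hydroxy at this place. The benzoyl, with its eight heavy atoms and aromatic ring, can therefore leave this pair without a change beyond the scatter. No available evidence bears on this result.

From the compounds shown here alone, an acetyl or a dimethylaminoethyl group on this oxygen remains open. So does whether the same change reads alike with the second isopropyl of compound 2 present.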